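The source may hold more compounds than are shown below. What is called first, only, known or untested is meant among the compounds shown, and "the series" means these compounds.

Compound 1 `N#CC1=C(N)N(c2ccc(S(N)(=O)=O)cc2)C2=C(C(=O)CCC2)C1c1ccccc1`: 40%
Compound 2 `N#CC1=C(N)N(c2ccc(S(N)(=O)=O)cc2)C2=C(C(=O)CCC2)C1/C=C/c1ccccc1`: 45%
Compound 3 `COc1ccc(C2C(C#N)=C(N)N(c3ccc(S(N)(=O)=O)cc3)C3=C2C(=O)CCC3)cc1`: 100%

In a functional assay on Ehrlich cells (Mus musculus) for antiproliferative activity, read by trypan blue exclusion, with a stated time of 2 h, tested at 100 ug/mL (a higher number here means a stronger effect of the compound at the concentration tested, a lower number a weaker effect), compound 3 stands highest of the three numbers: a number 55 percentage points higher from compound 2 to compound 3 (beyond the scatter) and a number 60 percentage points higher from compound 1 to compound 3 (beyond the scatter), both beyond the scatter. Among the measured compounds shown here, the one step without compound 3, a number 5 percentage points higher from compound 1 to compound 2 (within the scatter), lies within the scatter. Compound 4 `N#CC1=C(N)N(c2ccc(S(N)(=O)=O)cc2)C2=C(C(=O)CCC2)C1c1cccc([N+](=O)[O-])c1` has not been measured; it differs from compound 3 in one place: 3-nitrophenyl in place of 4-methoxyphenyl on a saturated ring carbon. For the measured compounds named here, both large steps end at compound 3 and its methoxy group, which compound 4 gives up, and no measured step involves a nitro group, so the gain seen in compound 3 may not carry over. In this assay compound 4 is expected to give 55%, with a range from 25% to 90%, which means an expected step of a number 45 percentage points lower from compound 3 to compound 4 (beyond the scatter).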

Compound 4, a percentage reported as activity, at one concentration (the size of the read-out at that concentration, not a potency): 71%
The estimate for compound 4 lay 16 percentage points below the measured number, and the stated range covers the measured number.
By their numbers in this assay, from the lowest: compounds 1 and 2 (each within the scatter of the next); then compound 4; then compound 3.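

Methoxy is not the only group that lifts the number when added to the phenyl ring at this saturated ring carbon: nitro in place of hydrogen does so too (a number 31 percentage points higher from compound 1 to compound 4 (beyond the scatter)), and 3-nitrophenyl also outdoes 2-phenylethenyl (a number 26 percentage points higher from compound 2 to compound 4 (beyond the scatter)). Still, 3-nitrophenyl does not match 4-methoxyphenyl (a number 29 percentage points lower from compound 3 to compound 4 (beyond the scatter)). Nothing available explains these differences.

Because that last step changes both the group and its place on the phenyl ring, the two contributions cannot be separated. Going by these compounds, how an amine or a carboxylic acid on that ring would compare remains open.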